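Butyl in Place of Hydroxyphenyl on Compound 3

This account rests on a few compounds, and the source may have more. Where it says the series, first, only, none or still open, it means among the compounds named here.

Compound 1 `O=C1O/C(=C\Cn2cc(-c3ccc(Br)cc3)nn2)C(OCc2ccccc2)=C1OCc1ccccc1` gives only a limit of the assay in a functional assay on MCF7 cells (Homo sapiens) for antiproliferative activity, read by MTT assay, with a stated time of 72 h (a lower number here means a stronger inhibitor, a higher number a weaker inhibitor), > 100000 nM. Compound 2 `O=C1O[C@H]([C@@H](O)Cn2cc(-c3ccc(Br)cc3)nn2)C(OCc2ccccc2)=C1OCc1ccccc1` gives 5620 nM in this assay, and compound 3 `O=C1O[C@H]([C@@H](O)Cn2cc(-c3cccc(O)c3)nn2)C(OCc2ccccc2)=C1OCc1ccccc1` gives 51800 nM, the higher of the two numbers shown; the step between them is a 9.2-fold higher number from compound 2 to compound 3 (0.96 log units; beyond the scatter). Compound 4 `CCCCc1cn(C[C@H](O)[C@H]2OC(=O)C(OCc3ccccc3)=C2OCc2ccccc2)nn1` differs from compound 3 by butyl in place of 3-hydroxyphenyl on an aromatic carbon. Among the compounds with values here, no measured step replaces an aromatic group with a chain, so the only guidance is the aryl-to-aryl swap from compound 2 to compound 3, which was modest. The step of a 1.3-fold lower number from compound 3 to compound 4 (0.11 log units; within the scatter) in this assay is therefore expected to be modest and uncertain in direction. Compound 4 is estimated at 40000 nM, with a range from 10000 nM to 150000 nM.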

Compound 4, half-maximal inhibitory concentration: 7910 nM
Compound 4: middle estimate off by 5.1-fold (0.70 log units), on the high side; measured number below the stated range.
By their numbers in this assay, from the lowest: compounds 2 and 4 (each within the scatter of the next); then compound 3. At a limit, above all of these: compound 1.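

In this assay, this position does not need an aromatic ring: the change to butyl, which has no ring, gives a 6.5-fold lower number from compound 3 to compound 4 (0.82 log units; beyond the scatter). Against the other aryl group, the same chain gives a 1.4-fold higher number from compound 2 to compound 4 (0.15 log units; within the scatter), so butyl and 4-bromophenyl cannot be told apart here, and only 3-hydroxyphenyl stands apart among the three groups at this position. Nothing shown gives a reason for these results.

Open, as far as these compounds go, is whether a longer chain such as octyl or a shorter one such as methyl would give a similar number. Also open, from the compounds shown here alone, is how an amine or a carboxylic acid at the end of the butyl chain would fare.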